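The source may hold more compounds than are shown below. What is called first, only, known or untested is meant among the compounds shown, and "the series" means these compounds.

Compound 1 `Cc1nn(C)c(Oc2ccc(F)c(F)c2)c1/C=N\CCCCCCOc1cc2oc(=O)cc(C)c2cc1Cl` was tested in a functional assay on HepG2 cells (Homo sapiens) for antiproliferative activity, read by MTT assay, with a stated time of 72 h; a higher number here means a weaker inhibitor, a lower number a stronger inhibitor. In this assay compound 1 gives only a limit, > 25000 nM, so where it truly stands is not pinned down. Compound 2 `Cc1nn(C)c(Oc2ccc(I)cc2)c1/C=N\CCCCCCOc1cc2oc(=O)cc(C)c2cc1Cl` carries 4-iodophenyl in that place and gives 14200 nM in this assay. Within the data shown here, the one measured comparison is an at least 1.7-fold lower number from compound 1 to compound 2 (0.24 log units; that floor lies within the scatter). Compound 3 `Cc1ccccc1Oc1c(/C=N\CCCCCCOc2cc3oc(=O)cc(C)c3cc2Cl)c(C)nn1C` differs from compound 1 by 2-methylphenyl in place of 3,4-difluorophenyl on an oxygen on an aromatic ring. That measured step concerns a different group, so for compound 3 no step beyond the scatter is expected. Compound 3 is therefore estimated at 20000 nM, within 7000 nM to 60000 nM, an expected step of an at least 1.2-fold lower number from compound 1 to compound 3 (0.09 log units; that floor lies within the scatter) anchored on (the limit of > 25000 nM in this assay, at which 1 of the 2 values shown sits).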

Compound 3, half-maximal inhibitory concentration: 7830 nM
The estimate for compound 3 lay 2.6-fold (0.41 log units) above the measured number, within the range that was stated.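

In this assay, changing the group on this oxygen now gives a step beyond the scatter, with 2-methylphenyl in place of 3,4-difluorophenyl: an at least 3.1-fold lower number from compound 1 to compound 3 (0.50 log units; beyond the scatter). That size is only a floor, resting on a limit: the limit of > 25000 nM in this assay, at which 1 of the 3 values shown sits. The other change, 2-methylphenyl in place of 4-iodophenyl, does not separate the two groups: a 1.8-fold lower number from compound 2 to compound 3 (0.26 log units; within the scatter).

As far as these compounds go, whether the methyl group or the loss of both fluorines matters more stays open, as this change does both at once. From the compounds shown here alone, how a phenyl ring carrying an amine or a carboxylic acid would behave here also remains unknown.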